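The source may report more compounds than this note shows. Statements on the series, on what has been measured and on what is new or still open speak of the compounds shown alone.

In a functional assay on the whole organism with Scenedesmus acutus as the target (a lower number here means a stronger inhibitor, a higher number a weaker inhibitor), compound 1 `O=C(O)c1cc(N2C(=O)C3=C(CCCC3)C2=O)ccc1Cl` gives > 100000 nM, a limit and not a number. Compound 2 `CCCOC(=O)c1cc(N2C(=O)C3=C(CCCC3)C2=O)ccc1Cl`, the propyl ester, gives 1860 nM. Compound 3 `CC(C)(C)OC(=O)c1cc(N2C(=O)C3=C(CCCC3)C2=O)ccc1Cl`, the tert-butyl ester, gives 12900 nM, the higher of the two actual numbers in the series.

Compound 4 `CCCCCOC(=O)c1cc(N2C(=O)C3=C(CCCC3)C2=O)ccc1Cl` carries pentyl in place of tert-butyl on an oxygen next to a carbonyl group. Among the measured compounds shown here, the closest precedent is a 6.9-fold higher number from compound 2 to compound 3 (0.84 log units; beyond the scatter), a modest step between propyl and tert-butyl. Read in reverse, it is the best guide, as compound 4 has a straight chain, as does compound 2. Two further steps, an at least 53-fold lower number from compound 1 to compound 2 (1.73 log units; beyond the scatter) and an at least 7.7-fold lower number from compound 1 to compound 3 (0.88 log units; beyond the scatter), show that both esters lie well clear of the limit, but they say little about chain choice. A modest step to a lower number is therefore expected in this assay, estimated as a 5.2-fold lower number from compound 3 to compound 4 (0.71 log units; beyond the scatter). For compound 4 the estimated value is 2500 nM, with an expected range of 700 nM to 9000 nM.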

Compound 4, half-maximal inhibitory concentration: 9330 nM
Beside the measured number, compound 4's estimate is 3.7-fold (0.57 log units) below it; the measured number lies above the stated range.
By their numbers in this assay, from the lowest: compound 2; then compounds 4 and 3 (each within the scatter of the next). At a limit, above all of these: compound 1.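

In this assay, a straight chain on this oxygen does not by itself keep the level of compound 2: a 5.0-fold higher number from compound 2 to compound 4 (0.70 log units; beyond the scatter), so lengthening propyl to pentyl costs a modest amount. The change from tert-butyl to pentyl gives a 1.4-fold lower number from compound 3 to compound 4 (0.14 log units; within the scatter), which places the two groups within the scatter of each other, so a straight chain and a branched one are not always separated here, although compound 2 stands apart from compound 3. The pentyl ester also remains clear of the free acid, an at least 10-fold lower number from compound 1 to compound 4 (1.03 log units; beyond the scatter), a step with a number at only one end, as compound 1 stands at a limit: the limit of > 100000 nM in this assay, at which 1 of the 4 values shown sits.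

Butyl and hexyl esters would show whether the numbers climb steadily with chain length or change abruptly. An isopropyl ester would test branching at the size of propyl, and an amide in place of the ester would test whether the ester oxygen is needed.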